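The compounds below may be only part of what the source reports. "The series", "measured", "known", "first", "only" and "open" are said of these compounds alone.

The account concerns an assay on cells for inhibition of HSP60/HSP10 (Homo sapiens), with a stated time of 60 min; on this read-out lower numbers stand for stronger inhibition and higher numbers for weaker inhibition. Compound 1 `Cc1ccccc1S(=O)(=O)Nc1ccc2oc(-c3ccccc3)nc2c1` gives in this assay only a limit, > 100000 nM. Compound 2 `O=S(=O)(Nc1ccc(-c2nc3ccccc3o2)cc1)c1ccccc1O` likewise gives in this assay only a limit, > 100000 nM. Within the data shown here, compound 1 thus stands at the limit of > 100000 nM in this assay, at which 2 of the 2 values shown sit, and no step between measured compounds is available, so nothing in the measured set shows how a change at this position moves the read-out. The unmeasured compound 3 `O=S(=O)(Nc1ccc2oc(-c3ccccc3)nc2c1)c1ccc(O)cc1` differs from compound 1 in one place: 4-hydroxyphenyl in place of 2-methylphenyl on a sulfonyl sulfur. With both measured values sitting at the limit, the step from compound 1 to compound 3 in this assay is expected to be none beyond the scatter, that is a number no higher from compound 1 to compound 3 (the limit leaves the size open) as estimated here. Compound 3 is therefore expected to give in this assay about 100000 nM, with a range from 30000 nM to 300000 nM, and most likely again only a limit rather than a number.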

Compound 3, half-maximal inhibitory concentration: 88000 nM
Compound 3: the middle estimate sits 1.1-fold (0.06 log units) above what was measured, and the stated range covers the measured number.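

In this assay, among these compounds, 4-hydroxyphenyl in place of 2-methylphenyl on a sulfonyl sulfur gives an at least 1.1-fold lower number from compound 1 to compound 3 (0.05 log units; that floor lies within the scatter), the first step that can be read at this position. Among the compounds shown here, compound 3 supplies the first actual number in the set, 88000 nM. The step has only a floor, so it establishes no change beyond the scatter and leaves the true size open. The other values remain limits rather than numbers: the limit of > 100000 nM in this assay, at which 2 of the 3 values shown sit.

The compounds shown leave open whether the entering hydroxyl, the departing methyl or the different place of the substituent accounts for the number that compound 3 gives. Nor do they show what a plain phenyl, a 4-methylphenyl, a 4-aminophenyl or a 4-carboxyphenyl on the same sulfonyl sulfur would give in this assay.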